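The compounds below may be only part of what the source reports. "The series", "measured", "known", "first", "only" and "open" are said of these compounds alone.

Working notes on the series in a functional assay on HL-60 cells (Homo sapiens) for cytotoxicity, read by WST assay, with a stated time of 48 h; on this read-out higher numbers stand for an effect only at larger amounts of compound and lower numbers for an effect already at smaller amounts. Compound 1 `CCCCOc1ccc(/C=C2/C(=O)OC[C@@H]2Cc2ccccc2)cc1` reads > 100000 nM, which is a limit of the assay and not a number. Going by the values given here, compound 2 `COc1ccccc1C[C@H]1COC[C@@H]1Cc1ccc(Cl)c(Cl)c1` gives 55000 nM, the only actual number so far in this assay. Compound 3 `Cc1ccccc1C[C@H]1COC[C@@H]1Cc1ccc(Cl)c(Cl)c1` carries methyl in place of methoxy on an aromatic carbon, ortho to a large group (methyl in place of methoxy on an aromatic carbon). Among the compounds with values here, no measured step covers this change, so no shift beyond the scatter is expected, in either direction. The expected step is a 1.1-fold lower number from compound 2 to compound 3 (0.04 log units; within the scatter). For compound 3 the estimated value is 50000 nM, with an expected range of 25000 nM to 100000 nM.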

Compound 3, half-maximal effective concentration: 21000 nM
For compound 3 the middle estimate is 2.4-fold (0.38 log units) above the measured one, outside the stated range (below it).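

Replacing methoxy with methyl at this position in this assay gives a 2.6-fold lower number from compound 2 to compound 3 (0.42 log units; beyond the scatter) and so counts as a real change in the read-out. Going by these compounds alone, this is the first sign that the position responds to a small substituent change, and the methoxy oxygen is not needed for the effect seen in compound 2. Nothing shown here bears on why the number falls.

On these data alone, whether a hydroxyl, a chlorine or an ethyl at this position would move the number further remains open. So does whether the same change would give a similar step on a different core.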